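A few compounds are considered here, and "the series" means these few. Any claim that something is new, unique, unknown or untested is made for them only; others in the source may bear on it.

The compounds measured so far in a functional assay on A549 cells (Homo sapiens) for inhibition, read by CCK-8 assay, with a stated time of 48 h (on this read-out higher numbers stand for weaker inhibition and lower numbers for stronger inhibition), are these
- compound 1 `COc1cc(-c2ccnc3cc(-c4c[nH]c5ccccc45)nn23)cc(OC)c1OC` gives 29 nM
- compound 2 `COc1cc(-c2ccnc3cc(-c4ccc(C)c(C)c4)nn23)cc(OC)c1OC` gives 272 nM
- compound 3 `COc1cc(-c2ccnc3cc(-c4ccc5c(ccn5C)c4)nn23)cc(OC)c1OC` gives 15 nM

Compound 3 shares the low end of these numbers with compound 1, and the gap between them is a 1.9-fold lower number from compound 1 to compound 3 (0.29 log units; within the scatter) so no order can be drawn between the two. Compound 2 stands well apart, as shown by an 18-fold lower number from compound 2 to compound 3 (1.26 log units; beyond the scatter) and by a 9.4-fold higher number from compound 1 to compound 2 (0.97 log units; beyond the scatter) on the other side.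

Compound 4 `C=Cc1ccc(-c2cc3nccc(-c4cc(OC)c(OC)c(OC)c4)n3n2)cc1` carries 4-vinylphenyl in place of 1-methyl-1H-indol-5-yl on an aromatic carbon of compound 3, a change counted as 4-vinylphenyl in place of 1-methyl-1H-indol-5-yl on an aromatic carbon and leaving the rest of the structure as it was. Compound 2 is the nearest guide, since it too has a six-membered aromatic ring of carbon only at this place and no indole. Its large step suggests a clear rise, although the vinyl group itself has not been tested. The step expected is a 12-fold higher number from compound 3 to compound 4 (1.08 log units; beyond the scatter) and it points to weaker inhibition. Compound 4 is therefore estimated at 180 nM with an expected range from 50 nM to 600 nM in this assay as the read-out.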

Compound 4, half-maximal inhibitory concentration: 1030 nM
The estimate for compound 4 lay 5.7-fold (0.76 log units) below the measured number, and the stated range ends below it.
By their numbers in this assay, from the lowest: compounds 3 and 1 (each within the scatter of the next); then compound 2; then compound 4.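

In this assay, the result shows that a six-membered aromatic ring of carbon only at this position can fall much further behind the indoles than compound 2 had indicated: replacing 1-methyl-1H-indol-5-yl with 4-vinylphenyl gives a 69-fold higher number from compound 3 to compound 4 (1.84 log units; beyond the scatter), and the comparison with the 1H-indol-3-yl compound gives a 36-fold higher number from compound 1 to compound 4 (1.55 log units; beyond the scatter). It also shows that the groups on that ring matter, not only the absence of an indole, as 4-vinylphenyl in place of 3,4-dimethylphenyl gives a 3.8-fold higher number from compound 2 to compound 4 (0.58 log units; beyond the scatter). No measurement is available to explain these steps.

The compounds shown leave open whether the vinyl group or the missing indole accounts for more of the rise. From the compounds shown here alone, how a 4-ethylphenyl or a 4-aminophenyl group would stand at this position also remains open.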